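Adding a chloro group to compound 2

This account rests on a few compounds, and the source may have more. Where it says the series, first, only, none or still open, it means among the compounds named here.

The study concerns a series built on a shared core, with compound 1 `Cc1nc(-c2ccccc2)sc1C(=O)CSc1nc(-c2cccc(Cl)c2)c(C#N)c(=O)[nH]1` and compound 2 `COc1ccc(-c2nc(C)c(C(=O)CSc3nc(-c4ccccc4)c(C#N)c(=O)[nH]3)s2)cc1` measured in a functional assay on U-87MG ATCC cells for antiproliferative activity against U-87 MG (Homo sapiens), read by MTT assay, with a stated time of 48 h, tested at 50 uM; a higher number here means a weaker effect of the compound at the concentration tested, a lower number a stronger effect. In this assay compound 1 gives 50.6%, while compound 2 gives 72.5%, the highest of the two numbers; the gap between the two lies beyond the scatter of the measurement. Compound 1 and compound 2 differ in more than one place, so nothing is told here about a single step between them.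

Compound 3 `COc1ccc(-c2nc(C)c(C(=O)CSc3nc(-c4cccc(Cl)c4)c(C#N)c(=O)[nH]3)s2)cc1` has not yet been measured in this assay. It differs from compound 2 in one place: chloro in place of hydrogen on an aromatic carbon. Within the data shown here, no step between measured compounds that corresponds to this change is available, so its size is not known from the data. Given that compound 1, which carries the same chloro group on its own phenyl ring, gives 50.6%, a modest move toward a lower number is expected for compound 3, though one within or near the scatter is also plausible.

Compound 3 is therefore expected to give 62% in this assay, within a range of 45% to 80%, corresponding to an expected step of a number 10.5 percentage points lower from compound 2 to compound 3 (beyond the scatter).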

Compound 3, a percentage reported as activity, at one concentration (the size of the read-out at that concentration, not a potency): 83.4%
Beside the measured number, compound 3's estimate is 21.4 percentage points below it; the whole stated range lies below it.
By their numbers in this assay, from the lowest: compound 1; then compound 2; then compound 3.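

In this assay, among these compounds, the change from phenyl to 3-chlorophenyl on the compound carrying the methoxy group gives the first single-place reading at this position, and it moves toward a weaker effect at the concentration tested (a number 10.9 percentage points higher from compound 2 to compound 3 (beyond the scatter)); at this position, on this compound, chloro in place of hydrogen therefore does not lower the number. The second single-place reading concerns the other aromatic ring: with the 3-chlorophenyl group held in place, methoxy in place of hydrogen gives a step printed as large and in the same direction (a number 32.8 percentage points higher from compound 1 to compound 3 (beyond the scatter)), so both changes lead toward compound 3 and its weaker effect. Nothing in the data shown accounts for the direction of either step.

From the compounds shown here alone, it remains open whether the chloro step keeps its direction and size when the methoxy group is absent, and whether the methoxy step does so when the chloro group is absent. Also open is how an amine or a carboxylic acid at the same aromatic carbon would read, since only hydrogen and chloro appear there among these compounds.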